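Working notes: from 1-phenylethyl to 6-aminohexyl

This account rests on a few compounds, and the source may have more. Where it says the series, first, only, none or still open, it means among the compounds named here.

Results so far in a functional assay on MCF7 cells (Homo sapiens) for cytotoxicity, read by MTT assay, with a stated time of 72 h (on this read-out higher numbers stand for weaker inhibition and lower numbers for stronger inhibition), follow:
- compound 1 `Nc1cccc(Nc2c(C(=O)NCc3ccc(F)cc3)nc(Br)c3cccnc23)c1` gives 8000 nM
- compound 2 `C[C@H](Nc1c(C(=O)NCc2ccc(F)cc2)nc(Br)c2cccnc12)c1ccccc1` gives "not determined" (no result reported)
- compound 3 `NCCCCCCNc1c(C(=O)NCc2ccc(F)cc2)nc(Br)c2cccnc12` awaits measurement

On these data alone, compound 2 has no number ("not determined" (no result reported)), so its standing in this assay remains open, and the series holds a single value to work from. The change under review is 6-aminohexyl in place of 1-phenylethyl on a nitrogen on an aromatic ring and puts 6-aminohexyl in place of 1-phenylethyl on a nitrogen on an aromatic ring. Within the data shown here, no step from compound 2 can be sized, since one end of it lacks a number. Measured against compound 1 (8000 nM), a moderate shift towards stronger inhibition, somewhat beyond the scatter, is expected, though one value offers weak support. Compound 3 is estimated at 3000 nM (expected range 800 nM to 12000 nM).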

Compound 3, half-maximal inhibitory concentration: 2000 nM
Compound 3: middle estimate off by 1.5-fold (0.18 log units), on the high side; low and high end bracket the measured number.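

In this assay, the nitrogen on an aromatic ring carries an open chain with no ring as well as an aromatic substituent, and a 4.0-fold lower number from compound 1 to compound 3 (0.60 log units; beyond the scatter) gives the first readable size of a change at this position, with 6-aminohexyl in place of 3-aminophenyl. On these data alone, the change from 1-phenylethyl to 6-aminohexyl cannot be read, as compound 2 has no number, so that group's standing remains unknown. No supporting data bear on the origin of the step from 3-aminophenyl to 6-aminohexyl.

The compounds shown leave open whether the terminal amine or the hexyl chain goes with the lower number, a question that a plain hexyl group or a terminal hydroxyl on the same chain would address. As far as these compounds go, how the value depends on chain length also stays open, for a butyl or an octyl chain ending in an amine.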